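Chloro for fluoro on the urea aryl ring

The source may hold more compounds than are shown below. What is called first, only, known or untested is meant among the compounds shown, and "the series" means these compounds.

Compound 3 `COc1cc2ncnc(NCc3cccc(NC(=O)Nc4ccccc4F)c3)c2cc1OC` gives 24900 nM in a functional assay on HepG2 cells (Homo sapiens) for antiproliferative activity, read by MTT assay (on this read-out lower numbers stand for stronger inhibition and higher numbers for weaker inhibition), the highest of the two numbers shown; nearest is compound 1 `COc1cc2ncnc(NCc3cccc(NC(=O)Nc4ccccc4)c3)c2cc1OC` with 19700 nM, and that gap, a 1.3-fold higher number from compound 1 to compound 3 (0.10 log units; within the scatter), lies within the scatter. Compound 2 `COc1cc2ncnc(NCc3cccc(NC(=O)Nc4ccc(C)cc4)c3)c2cc1OC` reached only the assay limit, > 50000 nM (the limit of > 50000 nM in this assay, at which 1 of the 3 values shown sits). Compound 4 `COc1cc2ncnc(NCc3cccc(NC(=O)Nc4ccccc4Cl)c3)c2cc1OC` differs from compound 3 by chloro in place of fluoro on an aromatic carbon. For the measured compounds named here, two measured steps touch the same aromatic carbon: the fluoro step stayed flat, while an at least 2.5-fold higher number from compound 1 to compound 2 (0.40 log units; beyond the scatter) was the one change there that moved the number; an at least 2.0-fold lower number from compound 2 to compound 3 (0.30 log units; that floor lies within the scatter) is capped by the limit. A halogen-for-halogen swap is expected to move the number less than an at least 2.5-fold higher number from compound 1 to compound 2 (0.40 log units; beyond the scatter) did. The expected step is a 1.1-fold higher number from compound 3 to compound 4 (0.05 log units; within the scatter), within the scatter. Compound 4 is estimated at 28000 nM, range 12000 nM to 60000 nM.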

Compound 4, half-maximal inhibitory concentration: 25500 nM
Compound 4: middle estimate off by 1.1-fold (0.04 log units), on the high side, within the range that was stated.
By their numbers in this assay, from the lowest: compounds 1, 3 and 4 (each within the scatter of the next). At a limit, above all of these: compound 2.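

In this assay, for the compounds shown here, a 1.0-fold higher number from compound 3 to compound 4 (0.01 log units; within the scatter) is the first halogen-for-halogen step on this aromatic carbon, ortho to a large group, and it lies within the scatter; a 1.3-fold higher number from compound 1 to compound 4 (0.11 log units; within the scatter) also lies within it, so chloro, like fluoro, stays level with hydrogen here. The remaining step, an at least 1.9-fold lower number from compound 2 to compound 4 (0.29 log units; that floor lies within the scatter), has a floor within the scatter and gives no size. Compound 2 stands at a limit, not a number: the limit of > 50000 nM in this assay, at which 1 of the 4 values shown sits.

On these data alone, whether an amine or a carboxylic acid on this aromatic carbon would stand apart from compounds 1, 3 and 4 remains open.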